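Swapping Chloro for Cyano in a Low-Toxicity Series

The source may hold more compounds than are shown below. What is called first, only, known or untested is meant among the compounds shown, and "the series" means these compounds.

Going by the values given here, in an ADME assay on L6 cells (Rattus norvegicus) for cytotoxicity, read by resazurin assay, with a stated time of 72 h (a lower number here means a stronger inhibitor, a higher number a weaker inhibitor), compound 2 `OC(c1ccc(Cl)cc1)(c1cccnc1)c1ccc(Cl)cc1F` gives 59400 nM, the only true number among the three compounds measured. Compound 1 `N#Cc1ccc(C(O)(c2ccc(Cl)cc2)c2cccnc2)cc1` gives > 100000 nM, which is a limit. Compound 3 `OC(c1ccc(C(F)(F)F)cc1)(c1cccnc1)c1ccc(Cl)cc1F` gives > 100000 nM, also a limit. Compound 4 `N#Cc1ccc(C(O)(c2ccc(Cl)cc2)c2cccnc2)c(F)c1` carries cyano in place of chloro on an aromatic carbon. Among the compounds with values here, the one measured step that bears on this change is an at least 1.6-fold higher number from compound 2 to compound 3 (0.22 log units; that floor lies within the scatter), where trifluoromethyl replaces chloro on an aromatic carbon. From the compounds shown here alone, that step is capped by the limit of > 100000 nM in this assay, at which 2 of the 3 values shown sit, so its true size is unknown. A small rise toward weaker inhibition is therefore expected, and the estimated step is a 1.5-fold higher number from compound 2 to compound 4 (0.18 log units; within the scatter). For compound 4 the expected value is 90000 nM, within an estimated range of 45000 nM to 170000 nM.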

Compound 4, half-maximal inhibitory concentration: > 100000 nM
Compound 4: no number, only a limit; the forecaster's own chance of this, stated with the estimate: 55%; middle value at least 1.1-fold (0.04 log units) away from the limit.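

Cyano in place of the chloro that sits meta to a fluoro group gives an at least 1.6-fold higher number from compound 2 to compound 4 (0.22 log units; that floor lies within the scatter). Compound 3 changed the other chloro, so this shows that a replacement at this second position also gives no number lower than that of compound 2 in this assay. The true size of the step remains unknown: the limit of > 100000 nM in this assay, at which 3 of the 4 values shown sit.

The step from compound 1 to compound 4, with fluoro in place of hydrogen, cannot be read, as both values are limits. From the compounds shown here alone, whether an amine or a carboxylic acid at this position would give a true number stays open.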